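The source may hold more compounds than are shown below. What is called first, only, known or untested is meant among the compounds shown, and "the series" means these compounds.

Measured so far, in a functional assay on A-431 cells (Homo sapiens) for inhibition, read by MTT assay, with a stated time of 72 h; on this read-out higher numbers stand for weaker inhibition and lower numbers for stronger inhibition:

- compound 1, `CC(C)(C)Oc1ccc(-c2nnc(SCCCN3CCN(c4nc5ccccc5o4)CC3)o2)cc1`: 65800 nM
- compound 2, `Oc1ccc(-c2nnc(SCCCN3CCN(c4nc5ccccc5o4)CC3)o2)cc1`: 117000 nM
- compound 3, `CC(C)(C)Oc1ccc(-c2nnc(SCCCN3CCN(c4nc5ccccc5s4)CC3)o2)cc1`: 67000 nM

Working notes on the series. Among the compounds with values here, all three numbers in this assay sit close together, and no compound can be called stronger or weaker than another on this evidence. Compound 1 and compound 2 differ only in one place: hydrogen in place of tert-butyl on an oxygen on an aromatic ring. This change gave a 1.8-fold higher number from compound 1 to compound 2 (0.25 log units; within the scatter). Compound 1 and compound 3 differ only in their cores: 1,3-benzothiazol-2-yl in place of 1,3-benzoxazol-2-yl on an amine nitrogen in a ring. Here the step was a 1.0-fold higher number from compound 1 to compound 3 (0.01 log units; within the scatter), so the two cores behave alike as far as these two compounds show.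

Compound 4, `Oc1ccc(-c2nnc(SCCCN3CCN(c4nc5ccccc5s4)CC3)o2)cc1`, has not yet been measured in this assay. It stands to compound 3 as compound 2 stands to compound 1: hydrogen in place of tert-butyl on an oxygen on an aromatic ring. The place of the change is described in the same words for both pairs, so this is the same change, made a second time, now on the core of compound 3. Its one earlier occurrence, from compound 1 to compound 2, stayed within the scatter, and the two cores gave the same number in the step from compound 1 to compound 3. On that basis the step from compound 3 to compound 4 is expected to be about a 1.8-fold higher number from compound 3 to compound 4 (0.25 log units; within the scatter), small and most likely within the scatter. For compound 4 the estimate in this assay is 118000 nM, with a range from 60000 nM to 240000 nM held to be plausible.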

Compound 4, half-maximal inhibitory concentration: 54700 nM
Compound 4: middle estimate off by 2.2-fold (0.33 log units), on the high side, and the stated range ends above it.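

Removing the tert-butyl group on the core of compound 3 gave a 1.2-fold lower number from compound 3 to compound 4 (0.09 log units; within the scatter) in this assay, and this step does not separate from the earlier step on the core of compound 1: the same change on two cores in this assay, a 1.8-fold higher number (0.25 log units; within the scatter) from compound 1 to compound 2 and a 1.2-fold lower number (0.09 log units; within the scatter) from compound 3 to compound 4, 2.2-fold (0.34 log units) apart, within the scatter of two such steps

The matching core exchange between the two hydroxy compounds gave a 2.1-fold lower number from compound 2 to compound 4 (0.33 log units; beyond the scatter), the only modest step beyond the scatter here, yet it too does not separate from its counterpart in the tert-butoxy pair: the same change on two cores in this assay, a 1.0-fold higher number (0.01 log units; within the scatter) from compound 1 to compound 3 and a 2.1-fold lower number (0.33 log units; beyond the scatter) from compound 2 to compound 4, 2.2-fold (0.34 log units) apart, within the scatter of two such steps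

Within the data shown here, the tert-butoxy to hydroxy change can therefore be carried between these two cores with no difference that the data can resolve, but this rests on only two small steps and does not show that the change has the same size, or even the same direction, on these cores, or that it would carry to any other core.

The compounds shown leave open whether a different group on that oxygen, such as methyl or a chain ending in an amine or a carboxylic acid, would move the number in this assay clearly away from the values seen so far. They also leave open what a longer linking chain would do on either core.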